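This account rests on a few compounds, and the source may have more. Where it says the series, first, only, none or still open, it means among the compounds named here.

Measured so far, in a physicochemical assay for solubility, read by LC-MS, in phosphate buffer, measured as thermodynamic solubility, with a stated time of 24 h, at pH 7.4; a lower number here means a less soluble compound, a higher number a more soluble compound:
- compound 1, `Cn1cc(-c2cnc3[nH]cc(-c4ccccc4)c3c2)cn1`: 20000 nM
- compound 2, `Cc1ccc(-c2c[nH]c3ncc(-c4cnn(C)c4)cc23)cc1`: 7000 nM
- compound 3, `N#Cc1cccc(-c2n[nH]c3ncc(-c4cnn(C5CCOCC5)c4)cc23)c1`: 700 nM

Compound 1 and compound 2 differ in one place, (methyl in place of hydrogen on an aromatic carbon), and this gave a 2.9-fold lower number from compound 1 to compound 2 (0.46 log units; beyond the scatter) in this assay. Compound 3 stands lowest of the three; against compound 2 and compound 1 its number is clearly the smaller, but the two cores differ in more than one place and that difference is not broken down here.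

Compound 4, `Cc1c(-c2cnn(C3CCOCC3)c2)cnc2[nH]nc(-c3cccc(C#N)c3)c12`, is not yet measured. It differs from compound 3 by methyl in place of hydrogen on an aromatic carbon, the same kind of change as that from compound 1 to compound 2. The surroundings are not the same: in compound 2 the methyl sits on a six-membered aromatic ring of carbon only, para to a large group; in compound 4 it sits on a six-membered aromatic ring with one nitrogen, part of a fused system of two rings, ortho to a fused ring and to a large group, opposite the ring nitrogen.

Resting on compound 3 at 700 nM and on the size of the measured step, the expected step is a 2.3-fold lower number from compound 3 to compound 4 (0.37 log units; beyond the scatter). For compound 4 the estimate in this assay is 300 nM, expected between 100 nM and 900 nM.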

Compound 4, solubility: 2000 nM
Compound 4: middle estimate off by 6.7-fold (0.82 log units), on the low side, outside the stated range (above it).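

In this assay, methyl in place of hydrogen on an aromatic carbon gave a 2.9-fold higher number from compound 3 to compound 4 (0.46 log units; beyond the scatter), whereas the same kind of change on the core of compound 1 gave a 2.9-fold lower number from compound 1 to compound 2 (0.46 log units; beyond the scatter), so the direction of this step did not carry from one core to the other. This does not show that the core alone sets the direction: in compound 4 the methyl stands on a six-membered aromatic ring with 1 nitrogen, part of a fused or bridged system of two rings, while in compound 2 it stands on a carbon-only aromatic ring, so core and place change together across just one pair on each core. Nothing available accounts for the reversal.

Open, from the compounds shown here alone, is whether ethyl, an amine or a carboxylic acid in place of the methyl of compound 4 would move the number in the same direction. Also open, going by these compounds, is whether methyl on the carbon-only aromatic ring of compound 3 would follow the step seen for compound 2.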